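Benzyl-to-hydrogen steps across two cores: cytotoxicity notes

The source may hold more compounds than are shown below. What is called first, only, known or untested is meant among the compounds shown, and "the series" means these compounds.

Measured so far:
compound 1 `COc1cc(OC)c2cc(-c3ccc(OCc4ccccc4)cc3)c(O)nc2c1`, a functional assay on A 172 cells (Homo sapiens) for cytotoxicity, read by colorimetric assay and MTT assay; a lower number here means a stronger inhibitor, a higher number a weaker inhibitor: 10000 nM
compound 2 `COc1ccc(-c2cc3c(OC)cc(OC)cc3n(CC(=O)OCc3ccccc3)c2=O)cc1`, this assay: 10000 nM
compound 3 `COc1ccc(-c2cc3c(OC)cc(OC)cc3n(CC(=O)O)c2=O)cc1`, this assay: 10000 nM

All three sit level with one another within the scatter. The change hydrogen in place of benzyl on an oxygen next to a carbonyl group produced no change at the digits printed from compound 2 to compound 3 (within the scatter). The difference between the core of compound 1 and the core of compound 2 is not broken down here; their values show no separation.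

Compound 4 `COc1cc(OC)c2cc(-c3ccc(O)cc3)c(O)nc2c1` is not yet measured. It differs from compound 1 by hydrogen in place of benzyl on an oxygen on an aromatic ring. The place is not the same as in the earlier pair: there the oxygen was next to a carbonyl group whose other neighbours are carbonyl carbon, here it is on an aromatic ring whose other neighbours are aromatic carbon, so this is the same kind of change rather than the same change.

Because no change at the digits printed from compound 2 to compound 3 (within the scatter) showed no movement, the expected step is no change at the digits printed from compound 1 to compound 4 (within the scatter). Compound 4 is therefore estimated at 10000 nM, with a wide band of 4000 nM to 25000 nM.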

Compound 4, half-maximal inhibitory concentration: 10000 nM
For compound 4 middle estimate and measured number coincide at the digits printed; measured number inside the range.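

In this assay, hydrogen in place of benzyl on an oxygen on an aromatic ring gives no change at the digits printed from compound 1 to compound 4 (within the scatter). Set beside the step on the other core, the two agree: the same change on two cores in this assay, no change at the digits printed (within the scatter) from compound 2 to compound 3 and no change at the digits printed (within the scatter) from compound 1 to compound 4, 1.0-fold (0.00 log units) apart, within the scatter of two such steps. This agreement is only between two steps without movement, at two different places, so it does not show that a step of measurable size would carry from one core to the other.

Still open, as far as these compounds go, is whether an amine or a longer chain in place of benzyloxy on the core of compound 1 would separate from the level of compound 4 at 10000 nM. The same question stands for an amine in place of the carboxylic acid of compound 3.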